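The compounds below may be only part of what the source reports. "The series", "measured", "known", "first", "only" and "open" are said of these compounds alone.

For the measured compounds named here, compound 2 `CCCCCCCCN1CC(=O)N(C)[C@@H](Cc2ccc(-c3cc(OC)c(OC)c(OC)c3)cc2)C1=O` gives 400 nM in a functional assay for agonist activity at follicle-stimulating hormone receptor (Homo sapiens), read by a luciferase reporter (a lower number here means that less compound is needed, a higher number that more compound is needed for the effect), the highest of the two numbers known here; its nearest neighbour, compound 1 `CCCCCCNC(=O)CN1CC(=O)N(C)[C@@H](Cc2ccc(-c3cc(OC)c(OC)c(OC)c3)cc2)C1=O`, gives 3 nM. Going by the values given here, the only measured step, a 130-fold higher number from compound 1 to compound 2 (2.12 log units; beyond the scatter), concerns the loss of the hexylcarbamoyl group and not the length of the chain itself. Compound 3 `CCCCCCCN1CC(=O)N(C)[C@@H](Cc2ccc(-c3cc(OC)c(OC)c(OC)c3)cc2)C1=O` differs from compound 2 by hydrogen in place of methyl on a saturated chain carbon, seven bonds along the chain from an amide-type nitrogen in a ring. Among the compounds with values here, no measured step speaks to this change, so the step from compound 2 to compound 3 is expected to stay within the scatter, no change at the digits printed from compound 2 to compound 3 (within the scatter). Compound 3 is therefore estimated at 400 nM, between 150 nM and 1100 nM.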

Compound 3, half-maximal effective concentration: 2300 nM
Compound 3: middle estimate off by 5.8-fold (0.76 log units), on the low side, and the stated range ends below it.
By their numbers in this assay, from the lowest: compound 1; then compound 2; then compound 3.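

Hydrogen in place of methyl at this place is not a silent change: it gives (a 5.8-fold higher number from compound 2 to compound 3 (0.76 log units; beyond the scatter)) in this assay, so the length of the chain itself counts, which the earlier pair could not show. Set against compound 1, the gap widens to (a 770-fold higher number from compound 1 to compound 3 (2.88 log units; beyond the scatter)), a large step. Nothing offered here accounts for either step.

On these data alone, whether a longer chain would bring the number down further stays open. So does whether an amine or a carboxylic acid on this chain would come close to compound 1.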